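The source may report more compounds than this note shows. Statements on the series, on what has been measured and on what is new or still open speak of the compounds shown alone.

Measured so far:
compound 1 `CCc1ccc(-n2nc(-c3ccc(C(F)(F)F)cc3O)nc2-c2ccccc2O)cc1`: 107%
compound 2 `Oc1cc(C(F)(F)F)ccc1-c1nc(-c2ccccc2O)n(-c2ccc(Br)cc2)n1`: 100%

In a functional assay on PC-12 cells (Rattus norvegicus) for cytotoxicity, read by MTT assay, with stated times of 2 h and 24 h, tested at 10 uM (on this read-out lower numbers stand for a weaker effect and higher numbers for a stronger effect at the one concentration tested), compound 1 gives 107% and compound 2 gives 100%; the step between them is a number 7 percentage points lower from compound 1 to compound 2 (within the scatter), so both numbers stand together within the scatter. Compound 3 `COc1cccc(-n2nc(-c3ccc(C(F)(F)F)cc3O)nc2-c2ccccc2O)c1` is not yet measured. Its change from compound 2 is 3-methoxyphenyl in place of 4-bromophenyl on an aromatic nitrogen. Among the compounds with values here, the only measured step, a number 7 percentage points lower from compound 1 to compound 2 (within the scatter), also swapped a group on the phenyl carried on that aromatic nitrogen and stayed within the scatter; no measured compound carries a 3-methoxyphenyl. For compound 3 the expected step is therefore a number 1 percentage points higher from compound 2 to compound 3 (within the scatter), nothing beyond the scatter. Compound 3 is estimated at 101%, between 86% and 116%.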

Compound 3, a percentage reported as activity, at one concentration (the size of the read-out at that concentration, not a potency): 106%
The estimate for compound 3 lay 5 percentage points below the measured number; low and high end bracket the measured number.
By their numbers in this assay, from the lowest: compounds 2, 3 and 1 (each within the scatter of the next).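

In this assay, the aromatic nitrogen also carries a 3-methoxyphenyl with no step beyond the scatter (a number 6 percentage points higher from compound 2 to compound 3 (within the scatter); a number 1 percentage points lower from compound 1 to compound 3 (within the scatter)) and compound 3 stands with compound 1 and compound 2. The tolerated change at this position therefore extends beyond the 4-substituted phenyls to a 3-substituted phenyl with a hydrogen-bond acceptor. No supporting measurement is available to explain this result. As far as these compounds go, whether an amine or a carboxylic acid on this phenyl would shift the number remains open, as does any change to the two hydroxyphenyl groups.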